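A trifluoromethylphenyl replaces methoxyphenyl on a shared core

A few compounds are considered here, and "the series" means these few. Any claim that something is new, unique, unknown or untested is made for them only; others in the source may bear on it.

Of the compounds shown here, three that share one core have been measured in a functional assay on NCI-H226 cells (Homo sapiens) for inhibition, read by sulforhodamine B assay, with a stated time of 48 h, tested at 10 uM; on this read-out lower numbers stand for less inhibition and higher numbers for more inhibition at the one concentration tested (going by the name of the read-out). Compound 1 `c1ccc2c(-c3cn4ccnc4c(-c4ccc5ncn(C6CCCCC6)c5c4)n3)cccc2c1` gives 9.45%, compound 2 `c1cn2cc(-c3ccsc3)nc(-c3ccc4ncn(C5CCCCC5)c4c3)c2n1` gives 6.34%, and compound 3 `COc1ccccc1-c1cn2ccnc2c(-c2ccc3ncn(C4CCCCC4)c3c2)n1` gives 25.7%. Compound 3 stands highest of the three: a number 16.3 percentage points higher from compound 1 to compound 3 (beyond the scatter) and a number 19.4 percentage points higher from compound 2 to compound 3 (beyond the scatter), whereas a number 3.1 percentage points lower from compound 1 to compound 2 (within the scatter). Compound 4 `FC(F)(F)c1cccc(-c2cn3ccnc3c(-c3ccc4ncn(C5CCCCC5)c4c3)n2)c1` differs from compound 3 in one place: 3-(trifluoromethyl)phenyl in place of 2-methoxyphenyl on an aromatic carbon. For the measured compounds named here, no measured step involves 3-(trifluoromethyl)phenyl, so the only guidance comes from the two steps into compound 3, each modest and beyond the scatter, which show that exchanging the group at this position can move the read-out by a modest amount. Two of the three groups tried gave low numbers and one gave a higher number. Compound 4 is therefore expected to fall back toward the lower pair, with an estimated step of a number 10.7 percentage points lower from compound 3 to compound 4 (beyond the scatter) in this assay. The estimate for compound 4 is 15%, between 2% and 32%.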

Compound 4, a percentage reported as inhibition, at one concentration (the size of the read-out at that concentration, not a potency): 1.55%
Compound 4: middle estimate off by 13.5 percentage points, on the high side, outside the stated range (below it).
By their numbers in this assay, from the lowest: compounds 4, 2 and 1 (each within the scatter of the next); then compound 3.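

In this assay the 3-(trifluoromethyl)phenyl group does not keep the reading given by 2-methoxyphenyl, with a number 24.2 percentage points lower from compound 3 to compound 4 (beyond the scatter). Against the two other groups it cannot be told apart, with a number 4.8 percentage points lower from compound 2 to compound 4 (within the scatter) and a number 7.9 percentage points lower from compound 1 to compound 4 (within the scatter), so three of the four groups at this position read alike and compound 3 alone stands apart from all of them. Nothing at hand explains why this one group differs from the others.

The two phenyl groups differ both in their substituent and in where it sits on the ring, so the compounds shown do not separate these two changes. Going by these compounds, whether 3-methoxyphenyl or 2-(trifluoromethyl)phenyl would read like compound 3 or like compound 4 stays open, as does the reading of an aminophenyl or a carboxylic acid group at this position.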